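Ring Expansion Without Fluorine: Clearance Expectation for Compound 4

The compounds below may be only part of what the source reports. "The series", "measured", "known", "first", "only" and "open" are said of these compounds alone.

Compound 1 `O=C(NCC1(O)CCCC(F)(F)C1)c1cc(-c2ncc(F)cn2)ccc1Cl` was tested in an in vitro ADME assay on microsomes from liver (Homo sapiens) for metabolic stability (a higher number here means faster removal of the compound, a lower number slower removal), and gave 10 mL/min/kg. Among the two numbers recorded, compound 1 has the lowest; compound 2 `N#Cc1cccc(-c2ccc(Cl)c(C(=O)NCC3(O)CCCCCC3)c2)n1` gives 47 mL/min/kg in this assay, a gap beyond the scatter. Compound 3 `O=C(NCC1(O)CCCC(F)(F)CC1)c1cc(-c2ncc(F)cn2)ccc1Cl` reaches only a limit of this assay, < 8 mL/min/kg, and no number. Compound 4 `O=C(NCC1(O)CCCCCC1)c1cc(-c2ncc(F)cn2)ccc1Cl` has not yet been measured; it differs from compound 1 by 1-hydroxycycloheptyl in place of 3,3-difluoro-1-hydroxycyclohexyl on a saturated chain carbon bound to an amide-type nitrogen. Compound 2 also carries a 1-hydroxycycloheptyl group, although it differs from compound 4 elsewhere too. The step from compound 1 to compound 4 is expected to raise clearance, a 2.5-fold higher number from compound 1 to compound 4 (0.40 log units; beyond the scatter), beyond the scatter. Compound 4 is therefore estimated at 25 mL/min/kg, within 10 mL/min/kg to 60 mL/min/kg.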

Compound 4, clearance: 21 mL/min/kg
The estimate for compound 4 lay 1.2-fold (0.08 log units) above the measured number; the measured number falls inside the stated range.
By their numbers in this assay, from the lowest: compound 1; then compound 4; then compound 2. At a limit, below all of these: compound 3.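

In this assay, 1-hydroxycycloheptyl in place of 3,3-difluoro-1-hydroxycyclohexyl on a saturated chain carbon bound to an amide-type nitrogen gives a 2.1-fold higher number from compound 1 to compound 4 (0.32 log units; beyond the scatter). With 1-hydroxycycloheptyl common to both compounds, 5-fluoropyrimidin-2-yl in place of 6-cyanopyridin-2-yl on an aromatic carbon gives a 2.2-fold lower number from compound 2 to compound 4 (0.35 log units; beyond the scatter), so clearance at this ring also depends on the aromatic group. The step to compound 4 from compound 3 cannot be read, as compound 3 gives a limit and not a number: the limit of < 8 mL/min/kg in this assay, at which 1 of the 4 values shown sits.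

The step from compound 1 to compound 4 changes ring size and removes both fluorines together, leaving their shares unresolved. On these data alone, how a methoxy group or an amine in place of the hydroxyl would shift clearance also remains open.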